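A few compounds are considered here, and "the series" means these few. Any claim that something is new, unique, unknown or untested is made for them only; others in the source may bear on it.

Of the compounds shown here, two have been measured so far in an ADME assay on MAGI cells (Homo sapiens) for cytotoxicity; a lower number here means that less compound is tolerated, a higher number that more compound is tolerated. Compound 1 `NCCCCN(C[C@H]1CN(S(=O)(=O)c2cc3ccccc3s2)CCN1)[C@H]1CCCc2cccnc21` gives > 10 uM, which is a limit of the assay and not a number. Compound 2 `NCCCCN(C[C@H]1CN(S(=O)(=O)c2ccc(Cl)cc2)CCN1)[C@H]1CCCc2cccnc21` gives > 10 uM, again a limit and not a number, and that limit is all that can be said of where it stands.

Among the compounds with values here, the one measured step, a step that the two limits leave unreadable from compound 1 to compound 2, puts 4-chlorophenyl in place of 1-benzothiophen-2-yl on a sulfonyl sulfur, and its size cannot be read. The whole of the evidence is the limit of > 10 uM in this assay, at which 2 of the 2 values shown sit.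

Compound 3 `NCCCCN(C[C@H]1CNCCN1)[C@H]1CCCc2cccnc21` has not yet been measured. Its difference from compound 2 is hydrogen in place of (4-chlorophenyl)sulfonyl on an amine nitrogen in a ring. The measured step exchanged the group on the sulfonyl and kept the sulfonyl itself, so it offers no size or direction to carry over to this larger change.

The expected change is therefore only a rough estimate, a step that the limit leaves unreadable from compound 2 to compound 3, with no firm direction behind it. For compound 3 the estimate is 20 uM, with an expected range from 8 uM to 60 uM.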

Compound 3, half-maximal toxic concentration: > 10 uM
Compound 3 ended at the assay's limit; the forecaster's own chance of this, stated with the estimate: 75%; the middle value is on the limit's open side.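

The step from compound 2 to compound 3 cannot be read: in this assay, both compounds give a limit and not a number. The compounds shown leave open how much of any of them the cells tolerate, and whether hydrogen in place of (4-chlorophenyl)sulfonyl changes that amount: the limit of > 10 uM in this assay, at which 3 of the 3 values shown sit.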